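A few compounds are considered here, and "the series" means these few. Any claim that something is new, unique, unknown or untested is made for them only; others in the source may bear on it.

In a functional assay on HeLa cells (Homo sapiens) for antiproliferative activity, read by cell counting, with a stated time of 3 days (on this read-out higher numbers stand for weaker inhibition and lower numbers for stronger inhibition), compound 1 `CC(Nc1ccccc1Oc1cccc(F)c1)=C1C(=O)CC(c2ccccc2)CC1=O` gives 550 nM, compound 2 `CC(=O)c1ccc(Oc2ccccc2NC(C)=C2C(=O)CC(c3ccccc3)CC2=O)cc1` gives 130 nM and compound 3 `COc1ccc(Oc2ccccc2NC(C)=C2C(=O)CC(c3ccccc3)CC2=O)cc1OC` gives 54 nM. Compound 3 therefore has the lowest of the three numbers, and its steps to the other two lie beyond the scatter.

The next comparison is with compound 4 `CC(Nc1ccccc1Oc1ccccc1)=C1C(=O)CC(c2ccccc2)CC1=O`, which differs from compound 3 as follows: phenyl in place of 3,4-dimethoxyphenyl on an oxygen on an aromatic ring. In words, this is phenyl in place of 3,4-dimethoxyphenyl on an oxygen on an aromatic ring. Among the measured compounds shown here, no measured compound carries the plain phenyl, so the evidence is indirect.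

Two measured steps end at the 3,4-dimethoxyphenyl: a 10-fold lower number from compound 1 to compound 3 (1.01 log units; beyond the scatter), which is large, and a 2.4-fold lower number from compound 2 to compound 3 (0.38 log units; beyond the scatter), which is modest. A third, a 4.2-fold lower number from compound 1 to compound 2 (0.63 log units; beyond the scatter), shows that the group on this oxygen can move the number even when the 3,4-dimethoxyphenyl is absent. Neither of the two other groups matches the 3,4-dimethoxyphenyl, with compound 2 at 130 nM and compound 1 at 550 nM. A modest to large step towards a higher number is therefore expected in this assay.

The expected change is a 5.2-fold higher number from compound 3 to compound 4 (0.71 log units; beyond the scatter).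

Compound 4 is estimated at 280 nM, with an expected range from 100 nM to 800 nM.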

Compound 4, half-maximal inhibitory concentration: 79 nM
Compound 4: the middle estimate sits 3.5-fold (0.55 log units) above what was measured; measured number below the stated range.
By their numbers in this assay, from the lowest: compounds 3, 4 and 2 (each within the scatter of the next, the first and the last beyond it); then compound 1.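

In this assay the plain phenyl on this oxygen stands level with the 3,4-dimethoxyphenyl, with a 1.5-fold higher number from compound 3 to compound 4 (0.17 log units; within the scatter), and with the 4-acetylphenyl, with a 1.6-fold lower number from compound 2 to compound 4 (0.22 log units; within the scatter), so neither substituted ring is needed for a number in this range. Among the compounds shown here, the 3-fluorophenyl is the only one of these groups that parts from the plain phenyl beyond the scatter, with a 7.0-fold lower number from compound 1 to compound 4 (0.84 log units; beyond the scatter); the large gap between compound 1 and compound 3 therefore reads as fluoro going with a higher number, not as the two methoxy groups going with a lower one, although compound 2 and compound 3 remain beyond the scatter of each other. No measurement at hand accounts for why the numbers fall this way.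

As far as these compounds go, with a single fluorinated compound, it stays open whether the higher number belongs to fluoro in particular or would also come with a chloro group or a single methoxy on this phenyl. An amine or a carboxylic acid on the same ring would test whether the level stretch seen with compound 2, compound 3 and compound 4 extends to groups of another kind.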